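Ethyl Ester of Compound 3: What to Expect

The source may hold more compounds than are shown below. What is called first, only, known or untested is meant among the compounds shown, and "the series" means these compounds.

Compound 1 `CCOc1ccc(N(C)C)cc1-c1ncc(C(=O)O)c(=O)[nH]1` gives 0.3 mg/kg in a functional assay on the whole organism (strain Sprague-Dawley) for inhibition, with Rattus norvegicus as the target, with a stated time of 10 min; a lower number here means that less compound is needed, a higher number that more compound is needed for the effect. Compound 2 `CCOc1ccc(S(N)(=O)=O)cc1-c1ncc(C(=O)O)c(=O)[nH]1` reaches only a limit of this assay, > 50 mg/kg. Compound 3 `CCOc1ccc(S(=O)(=O)N(C)C(C)C)cc1-c1ncc(C(=O)O)c(=O)[nH]1` likewise shows only a limit, > 10 mg/kg.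

Compound 3 thus stands at a limit rather than a number (the limit of > 10 mg/kg in this assay, at which 1 of the 3 values shown sits), and compound 2 sits at another (the limit of > 50 mg/kg in this assay, at which 1 of the 3 values shown sits). Compound 4 `CCOC(=O)c1cnc(-c2cc(S(=O)(=O)N(C)C(C)C)ccc2OCC)[nH]c1=O` differs from compound 3 by ethyl in place of hydrogen on an oxygen next to a carbonyl group. The measured steps concern a different place: an at least 160-fold higher number from compound 1 to compound 2 (2.22 log units; beyond the scatter) and an at least 33-fold higher number from compound 1 to compound 3 (1.52 log units; beyond the scatter) both alter the group on the aromatic carbon, while a step that the two limits leave unreadable from compound 2 to compound 3. Within the data shown here, none touches the carboxy end, so no measured step bears on this change, and no step beyond the scatter is expected from compound 3 to compound 4. Compound 4 is estimated at 20 mg/kg, between 5 mg/kg and 100 mg/kg. That estimate means a step that the limit leaves unreadable from compound 3 to compound 4, with a limit again likely.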

Compound 4, dose for 50% inhibition: > 10 mg/kg
Compound 4: no number, only a limit (the forecaster's own chance of this, stated with the estimate: 70%); the middle value lies beyond the limit too.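

Among these compounds, compound 3 and compound 4 both end at a limit of the assay rather than a number, and no step between them can be read. The compounds shown leave open whether ethoxycarbonyl in place of carboxy changes the result in this assay at all.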